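Adding an isopropenyl group to the cyclohexenyl ring

This account rests on a few compounds, and the source may have more. Where it says the series, first, only, none or still open, it means among the compounds named here.

Measured compounds:
Compound 1, `CCOc1nc(N)nc2[nH]cnc12`: > 1000000 nM in an assay on HT-29 cells for inhibition of Methylated-DNA--protein-cysteine methyltransferase (Homo sapiens); a lower number here means a stronger inhibitor, a higher number a weaker inhibitor
Compound 2, `Nc1nc(OCC2=CCCCC2)c2nc[nH]c2n1`: 1600 nM in this assay

Of the two values shown for this assay, compound 1 gives > 1000000 nM, which is a limit of the assay and not a number. Going by the values given here, compound 2 stands as the only compound with a numerical value, and the step of an at least 620-fold lower number from compound 1 to compound 2 (2.79 log units; beyond the scatter) shows that replacing the methyl with cyclohex-1-en-1-yl on the chain carbon bound to the ring oxygen moves the read-out far past the limit of > 1000000 nM in this assay, at which 1 of the 2 values shown sits, into the measurable range.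

Compound 3, `C=C(C)[C@H]1CC=C(COc2nc(N)nc3[nH]cnc23)CC1`, differs from compound 2 by 1-methylethenyl in place of hydrogen on a saturated ring carbon. Among the compounds with values here, the single measured step, an at least 620-fold lower number from compound 1 to compound 2 (2.79 log units; beyond the scatter), concerns a different place and a different kind of change, so no measured step bears directly on this one. In the absence of a relevant precedent, the change is expected to leave the number near that of compound 2, with a step of a 1.1-fold lower number from compound 2 to compound 3 (0.03 log units; within the scatter) expected to fall within the scatter. Compound 3 is therefore estimated at 1500 nM, within a range of 400 nM to 6000 nM.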

Compound 3, half-maximal inhibitory concentration: 2600 nM
Compound 3: middle estimate off by 1.7-fold (0.24 log units), on the low side, and the stated range covers the measured number.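

In this assay, placing 1-methylethenyl on the saturated ring carbon gives a 1.6-fold higher number from compound 2 to compound 3 (0.21 log units; within the scatter), so this change does not separate compound 3 from compound 2. Where the earlier compounds showed only what the cyclohex-1-en-1-yl group does on the chain carbon, this result shows that a group of 3 carbon atoms can sit on the ring, three ring bonds from the ring atom that bears a large group, with the value staying in the measurable range. Compound 1 stays outside this comparison, since its value is a limit and not a number: the limit of > 1000000 nM in this assay, at which 1 of the 3 values shown sits.

From the compounds shown here alone, whether this position accepts other groups as readily remains open, for instance an amine, a carboxylic acid or a longer chain. The compounds shown also do not tell whether the mirror-image form of compound 3 would give a similar value.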